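Methylating the amide nitrogen of compound 2

The source may report more compounds than this note shows. Statements on the series, on what has been measured and on what is new or still open speak of the compounds shown alone.

Compound 2 `Cc1ccc(-c2nn(C(C)C)cc2C(=O)Nc2ccc(C)c(S(=O)(=O)N3CCOCC3)c2)cc1` stands second highest of the three numbers in an assay on isolated protein for antagonist activity at Bile acid receptor (Homo sapiens), read by TR-FRET, with a stated time of 20 min (a higher number here means a weaker inhibitor, a lower number a stronger inhibitor), where compound 2 gives 49.1 nM. Its nearest neighbour is compound 3 `Cc1ccc(NC(=O)c2cn(C(C)C)nc2-c2ccc(C(F)(F)F)cc2)cc1S(=O)(=O)N1CCOCC1`, which in this assay gives 77.5 nM; the step of a 1.6-fold higher number from compound 2 to compound 3 (0.20 log units; within the scatter) lies within the scatter. The furthest is compound 1 `Cc1ccc(-c2nn(-c3cccc(Cl)c3)cc2C(=O)Nc2ccc(C)c(S(=O)(=O)N3CCOCC3)c2)cc1`, which gives 10.4 nM in this assay, and the step of a 4.7-fold higher number from compound 1 to compound 2 (0.67 log units; beyond the scatter) is a modest one that lies beyond the scatter.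

Compound 4 `Cc1ccc(-c2nn(C(C)C)cc2C(=O)N(C)c2ccc(C)c(S(=O)(=O)N3CCOCC3)c2)cc1` differs from compound 2 in a single place: methyl in place of hydrogen on an amide-type nitrogen. Neither measured step touches this position. Within the data shown here, the step from compound 1 to compound 2 concerns the group on the aromatic nitrogen, and the step from compound 2 to compound 3 concerns a group on an aromatic carbon; a change at the amide-type nitrogen has no counterpart among the measured compounds. Among the measured compounds shown here, no step in this assay can therefore be read across, and both the size and the direction of the change remain open. As a cautious guess, compound 4 is expected to give a somewhat higher number, with a wide range. Compound 4 is estimated at 150 nM in this assay, between 30 nM and 1000 nM, which means an expected step of a 3.1-fold higher number from compound 2 to compound 4 (0.49 log units; beyond the scatter).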

Compound 4, half-maximal inhibitory concentration: 489 nM
Estimate against measurement, compound 4: 3.3-fold (0.51 log units) below; low and high end bracket the measured number.
By their numbers in this assay, from the lowest: compound 1; then compounds 2 and 3 (each within the scatter of the next); then compound 4.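

In this assay, the amide-type nitrogen proves to be a position that responds to a very small change: a 10-fold higher number from compound 2 to compound 4 (1.00 log units; beyond the scatter), and that step comes from one methyl taking the place of the amide hydrogen. The earlier compounds shown here varied only the group on the aromatic nitrogen and a group on an aromatic carbon, so they said nothing about this nitrogen; now a single added carbon is seen to move the number beyond the scatter, although compound 4, at 489 nM, still gives a measured inhibitory value in the nanomolar range. Nothing available here bears on why the number rises with this change.

The compounds shown leave open whether an ethyl group, a longer chain or a cyclopropyl ring on this nitrogen would raise the number further or bring it back down. Among these compounds, they also leave open whether the same methyl would cost as much on compound 1, with its 3-chlorophenyl group, or on compound 3, with its trifluoromethyl group, since this change is seen only on compound 2.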